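A chain on the nitrogen of compound 1

A few compounds are considered here, and "the series" means these few. Any claim that something is new, unique, unknown or untested is made for them only; others in the source may bear on it.

- compound 1 `Nc1ccc(C2=NNC(=O)CC2)cc1`: 46.4 ug/mL
- compound 2 `Nc1cccc(C2=NNC(=O)CC2)c1`: > 46.4 ug/mL

Among the compounds with values here, in a functional assay for inhibition, with Homo sapiens as the target (on this read-out lower numbers stand for an effect already at smaller amounts and higher numbers for an effect only at larger amounts of compound), compound 1 gives 46.4 ug/mL, the only actual number so far. Compound 2 reads > 46.4 ug/mL, which is a limit of the assay and not a number. Compound 3 `O=C1CCC(c2ccc(NC(=O)CCCCl)cc2)=NN1` keeps the core of compound 1 and changes in one place: (3-chloropropyl)carbonyl in place of hydrogen on a nitrogen on an aromatic ring. Within the data shown here, no measured step covers such a change, so the only anchor is compound 1 at 46.4 ug/mL, and no clear shift in either direction is expected in this assay. The estimated change is a 1.2-fold lower number from compound 1 to compound 3 (0.06 log units; within the scatter), which stays within the usual scatter. Compound 3 is expected near 40 ug/mL, with an estimated range of 12 ug/mL to 120 ug/mL.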

Compound 3, half-maximal effective concentration: > 46.4 ug/mL
Compound 3: only a limit was reported; the forecaster's own chance of this, stated with the estimate: 45%; at least 1.1-fold (0.06 log units) between middle value and limit.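

In this assay, (3-chloropropyl)carbonyl in place of hydrogen on a nitrogen on an aromatic ring gives a number no lower from compound 1 to compound 3 (the limit leaves the size open). Compound 3 reads > 46.4 ug/mL, which is a limit of the assay and not a number. So this chain on the nitrogen brings no measurable gain over the free amine, and the size of the step cannot be read: the limit of > 46.4 ug/mL in this assay, at which 2 of the 3 values shown sit.

From the compounds shown here alone, whether a smaller acetyl group on this nitrogen would give a readable number stays open. The same holds for a chain carrying an amine or a carboxylic acid instead of the chlorine.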